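The compounds below may be only part of what the source reports. "The series", "measured", "known", "first", "only" and "open" are said of these compounds alone.

Measured so far in a functional assay on HCT-116 cells (Homo sapiens) for inhibition, read by CCK-8 assay, with a stated time of 48 h; a higher number here means a weaker inhibitor, a lower number a stronger inhibitor:

- compound 1, `COc1cc(-c2ccnc3cc(-c4ccc(C)c(C)c4)nn23)cc(OC)c1OC`, gives 261 nM.
- compound 2, `COc1cc(-c2ccnc3cc(-c4cccc(C#N)c4)nn23)cc(OC)c1OC`, reaches only the limit of the assay, > 10000 nM, so no number is known for it.
- compound 3, `COc1cc(-c2ccnc3cc(-c4cn(C)c5ccccc45)nn23)cc(OC)c1OC`, gives 762 nM.

As far as these compounds go, compound 2 therefore stands at the weak end of the three: it sits at the limit of > 10000 nM in this assay, at which 1 of the 3 values shown sits, and its true number is unknown beyond that. Compound 4, `COc1cc(-c2ccnc3cc(-c4ccc(C(C)(C)C)cc4)nn23)cc(OC)c1OC`, differs from compound 2 in one place: 4-(tert-butyl)phenyl in place of 3-cyanophenyl on an aromatic carbon.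

Among the compounds with values here, two measured steps bear on this change. The step of an at least 38-fold higher number from compound 1 to compound 2 (1.58 log units; beyond the scatter) shows that putting the 3-cyanophenyl group in place of an alkyl-substituted phenyl goes with a large loss, and the step of an at least 13-fold lower number from compound 2 to compound 3 (1.11 log units; beyond the scatter) shows that removing the 3-cyanophenyl group in favour of another aromatic group brings a large gain. Compound 4 carries an alkyl-substituted phenyl, as compound 1 does, so a large step downward in this assay is expected, with some doubt about how close it comes to compound 1.

Compound 4 is therefore expected to give about 500 nM, with a range from 150 nM to 3000 nM. This estimate implies an expected step of an at least 20-fold lower number from compound 2 to compound 4 (1.30 log units; beyond the scatter).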

Compound 4, half-maximal inhibitory concentration: > 10000 nM
Compound 4 gave a limit, no number; the forecaster's own chance of this, stated with the estimate: 15%; at least 20-fold (1.30 log units) between middle value and limit.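

In this assay compound 4 joins compound 2 at a limit of the assay, not a number, so the step between them cannot be read: the limit of > 10000 nM in this assay, at which 2 of the 4 values shown sit.

The earlier compounds shown here left room to think that an alkyl-substituted phenyl group on this aromatic carbon would be enough to keep activity, yet 4-(tert-butyl)phenyl in place of 3,4-dimethylphenyl gives an at least 38-fold higher number from compound 1 to compound 4 (1.58 log units; beyond the scatter). The indole-bearing compound also keeps a clear lead, with an at least 13-fold higher number from compound 3 to compound 4 (1.11 log units; beyond the scatter), so among the compounds shown the loss is not confined to the nitrile of compound 2, and the alkyl pattern on the phenyl ring matters as well as the kind of group.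

The compounds shown do not separate the presence of the tert-butyl group from the absence of the two methyl groups of compound 1, and a ring with a single methyl, such as 4-methylphenyl, remains an open case. As far as these compounds go, how a phenyl ring carrying an amine or a carboxylic acid would behave on this carbon also stays open.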